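The source may report more compounds than this note shows. Statements on the series, on what has been measured and on what is new or still open speak of the compounds shown alone.

Measured so far in an assay on cells for inhibition of Voltage-dependent T-type calcium channel subunit alpha-1H (Homo sapiens), read by patch clamp, tested at 10 uM; on this read-out higher numbers stand for more inhibition at the one concentration tested (going by the name of the read-out) and lower numbers for less inhibition:
Compound 1 `O=C(CC1c2ccccc2N=C(SCCCCCN2CCCC2)N1c1ccc(-c2ccccc2)cc1)NCc1ccc(F)cc1` gives 69%.
Compound 2 `O=C(CC1c2ccccc2N=C(SCCCCCN2CCCC2)N1c1ccc(-c2ccc(F)cc2)cc1)NCc1ccc(F)cc1` gives 76.6%.
Compound 3 `CN(C)CCCCCSC1=Nc2ccccc2C(CC(=O)NCc2ccc(F)cc2)N1c1ccc(-c2ccccc2)cc1` gives 83.1%.

Compound 3 holds the highest of the three numbers, though compound 2 sits within the scatter of it; only compound 1 is separated from it beyond the scatter, by the step of a number 14.1 percentage points higher from compound 1 to compound 3 (beyond the scatter), a modest rise that goes with the change from pyrrolidin-1-yl to dimethylamino on the chain.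

Compound 4 `CN(C)CCCCCSC1=Nc2ccccc2C(CC(=O)NCc2ccc(F)cc2)N1c1ccc(-c2ccc(F)cc2)cc1` differs from compound 3 by one change: fluoro in place of hydrogen on an aromatic carbon. The same change has been measured once in the series, between the two pyrrolidin-1-yl compounds, where a number 7.6 percentage points higher from compound 1 to compound 2 (within the scatter) was recorded and stayed within the scatter. Going by the values given here, nothing else measured bears on the fluoro for hydrogen exchange, so the single step is the whole basis. On that basis the expected step in this assay from compound 3 to compound 4 is small, upward if anything, and not clearly beyond the scatter. The expected step is a number 3.9 percentage points higher from compound 3 to compound 4 (within the scatter). Compound 4 is therefore estimated at 87%, within a range from 75% to 96%.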

Compound 4, a percentage reported as inhibition, at one concentration (the size of the read-out at that concentration, not a potency): 84.8%
Compound 4: middle estimate off by 2.2 percentage points, on the high side; measured number inside the range.
By their numbers in this assay, from the lowest: compounds 1, 2, 3 and 4 (each within the scatter of the next, the first and the last beyond it).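

In this assay, the phenyl to 4-fluorophenyl change now has a second reading, a number 1.7 percentage points higher from compound 3 to compound 4 (within the scatter), so this exchange para to a large group stays within the scatter with either dimethylamino or pyrrolidin-1-yl at the chain end: the same change on two cores in this assay, a number 7.6 percentage points higher (within the scatter) from compound 1 to compound 2 and a number 1.7 percentage points higher (within the scatter) from compound 3 to compound 4, 5.9 percentage points apart, within the scatter of two such steps. The exchange of pyrrolidin-1-yl for dimethylamino, read again on the 4-fluorophenyl compounds, gives a number 8.2 percentage points higher from compound 2 to compound 4 (within the scatter), so its earlier step beyond the scatter is not repeated, although the two readings do not differ beyond the scatter of two such steps: the same change on two cores in this assay, a number 14.1 percentage points higher (beyond the scatter) from compound 1 to compound 3 and a number 8.2 percentage points higher (within the scatter) from compound 2 to compound 4, 5.9 percentage points apart, within the scatter of two such steps.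

As far as these compounds go, whether chloro, methoxy or nitrile on the same aromatic carbon would read like fluoro stays open, as does the reading of a chain ending in diethylamino or piperidin-1-yl. From the compounds shown here alone, every number here comes from one tested concentration, so potency itself also stays open.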